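The source may report more compounds than this note shows. Statements on the series, on what has been measured and on what is new or still open speak of the compounds shown alone.

Measured so far in an assay on LX2 cells for inhibition of COL1A1 promoter (Homo sapiens), read by a luciferase reporter, with a stated time of 24 h, tested at 50 uM; a higher number here means a stronger effect of the compound at the concentration tested, a lower number a weaker effect:

compound 1 `Cc1ccc(-n2cc(C(=O)Nc3cc(F)cc(F)c3)c(=O)c3ccc(N(C)C)nc32)cc1OCCCCCCC[N+]12CCN(CC1)CC2`: 9.71%
compound 2 `CN(C)c1ccc2c(=O)c(C(=O)Nc3cc(F)cc(F)c3)cn(-c3ccc(Cl)c(OCCCCCCC[N+]45CCN(CC4)CC5)c3)c2n1`: 18.7%
compound 3 `Cc1cc(-n2cc(C(=O)Nc3cc(F)cc(F)c3)c(=O)c3ccc(N(C)C)nc32)ccc1OCCCCCCC[N+]1(C)CCCC1`: 35.9%

Compound 1 and compound 2 share one core and differ in one place: chloro in place of methyl on an aromatic carbon. That exchange gave a number 9 percentage points higher from compound 1 to compound 2 (within the scatter), so the two read-outs cannot be told apart. Compound 3 is built on a different core; how its core differs from that of compound 1 is not broken down here. What is clear is that compound 3 stands above both, with its gap to compound 2 and to compound 1 beyond the scatter.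

Compound 4 `CN(C)c1ccc2c(=O)c(C(=O)Nc3cc(F)cc(F)c3)cn(-c3ccc(OCCCCCCC[N+]4(C)CCCC4)c(Cl)c3)c2n1` has not yet been measured. It arises from compound 3 by chloro in place of methyl on an aromatic carbon. Within the data shown here, this is the same kind of change as the one from compound 1 to compound 2, though not the same: in compound 2 the new chloro sits ortho to a large group and para to a large group, whereas in compound 4 it sits ortho to a large group and meta to a large group.

Because the earlier step, a number 9 percentage points higher from compound 1 to compound 2 (within the scatter), stayed within the scatter, a similar small step is expected here, a number 4.1 percentage points higher from compound 3 to compound 4 (within the scatter). Compound 4 is therefore estimated at 40%, most likely between 25% and 55%.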

Compound 4, a percentage reported as inhibition, at one concentration (the size of the read-out at that concentration, not a potency): 2.59%
Estimate against measurement, compound 4: 37.4 percentage points above, and the stated range ends above it.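

In this assay, putting chloro in place of methyl on the aromatic carbon gave a number 33.3 percentage points lower from compound 3 to compound 4 (beyond the scatter), which is a large drop rather than the small step seen before. Set side by side, the two results for this one exchange disagree: the same change on two cores in this assay, a number 9 percentage points higher (within the scatter) from compound 1 to compound 2 and a number 33.3 percentage points lower (beyond the scatter) from compound 3 to compound 4, 42.3 percentage points apart, beyond the scatter of two such steps. This shows that in this series the outcome of the exchange cannot simply be carried from one core to another, but two pairs do not show which difference between the cores matters, nor separate that difference from the changed place of the chloro relative to the large groups on the ring.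

The compounds shown leave open whether other groups on the same aromatic carbon, such as fluoro, methoxy or an amine, would also give results that depend on the core. They also leave open whether the drop from methyl to chloro would persist with a longer chain or a shorter chain joining the ring to the charged end group.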